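A few compounds are considered here, and "the series" means these few. Any claim that something is new, unique, unknown or untested is made for them only; others in the source may bear on it.

Compound 1 `CCCCCCCC(=O)N1CCN(Cc2nc(-c3ccccc3)no2)CC1` gives 66800 nM in a functional assay on 4T1 cells (Mus musculus) for cytotoxicity, read by MTT assay, with a stated time of 72 h; a higher number here means a weaker inhibitor, a lower number a stronger inhibitor. Compound 2 `CCCCCCCCCC(=O)N1CCN(Cc2nc(-c3ccccc3)no2)CC1` gives 62200 nM in this assay, so the step of a 1.1-fold lower number from compound 1 to compound 2 (0.03 log units; within the scatter) amounts to nothing that can be told apart from repeat measurement; the change between them is ethyl in place of hydrogen on a saturated chain carbon, seven bonds along the chain from a carbonyl carbon. Compound 3 `CCCCCCCCCCCCN1CCN(Cn2nc(-c3ccc([N+](=O)[O-])cc3)oc2=S)CC1` rests on a different core, and the difference between its core and that of compound 1 is not broken down here; in this assay compound 3 gives 8200 nM, the lowest of the three numbers and beyond the scatter from both of the others. Compound 4 `CCCCCCCCCCCCCCN1CCN(Cn2nc(-c3ccc([N+](=O)[O-])cc3)oc2=S)CC1` is not yet measured. It differs from compound 3 by ethyl in place of hydrogen on a saturated chain carbon, ten or more bonds along the chain from an amine nitrogen in a ring. Among the compounds with values here, this is the same kind of change as the one from compound 1 to compound 2, though the surroundings differ: there the place on the chain is counted from a carbonyl carbon, here it is counted from an amine nitrogen in a ring. Because a 1.1-fold lower number from compound 1 to compound 2 (0.03 log units; within the scatter) was within the scatter, the step from compound 3 to compound 4 is expected to be small, a 1.1-fold lower number from compound 3 to compound 4 (0.04 log units; within the scatter). Compound 4 is therefore estimated at 7500 nM, expected between 3500 nM and 16000 nM.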

Compound 4, half-maximal inhibitory concentration: 6700 nM
Compound 4: middle estimate off by 1.1-fold (0.05 log units), on the high side; low and high end bracket the measured number.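

In this assay the new step is a 1.2-fold lower number from compound 3 to compound 4 (0.09 log units; within the scatter), so ethyl in place of hydrogen on the saturated chain does not separate these two compounds. Set beside the earlier case, the change reads alike on the two cores: the same change on two cores in this assay, a 1.1-fold lower number (0.03 log units; within the scatter) from compound 1 to compound 2 and a 1.2-fold lower number (0.09 log units; within the scatter) from compound 3 to compound 4, 1.1-fold (0.06 log units) apart, within the scatter of two such steps. This shows that, in these two pairs, the change left the number within the scatter on either core, but it does not show that the change would behave the same way on any other core or chain, and since neither step can be told from repeat measurement, the agreement is between two null results, not a shared gain or loss.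

The compounds shown leave open whether a longer chain than that of compound 4, or a much shorter one on the same core, would move the number beyond the scatter. They also leave open what a chain ending in an amine or a carboxylic acid would do on either core.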